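A few compounds are considered here, and "the series" means these few. Any claim that something is new, unique, unknown or untested is made for them only; others in the source may bear on it.

Measured so far:
Compound 1 `CCCCCCCCS(=O)(=O)Nc1ccc(C(=O)c2ccc(OC)cc2)cc1C(=O)O`: 44300 nM
Compound 2 `CCCCCCCCS(=O)(=O)Nc1ccc(/C=C/c2ccccc2)cc1C(=O)O`: 16300 nM

Both numbers come from an assay on mitochondria (strain BALB/c) for inhibition of glycerol-3-phosphate acyltransferase 1, mitochondrial (Mus musculus), read by scintillation counting, with a stated time of 10 min (on this read-out higher numbers stand for weaker inhibition and lower numbers for stronger inhibition), and compound 2 stands at the lower of the two. Within the data shown here, only one step is known, a 2.7-fold lower number from compound 1 to compound 2 (0.43 log units; beyond the scatter), and it swapped the whole side group: a (4-methoxyphenyl)carbonyl left and a 2-phenylethenyl entered, so the link to the ring and the methoxy changed in one move.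

Compound 3 `CCCCCCCCS(=O)(=O)Nc1ccc(CCc2ccc(OC)cc2)cc1C(=O)O` has not yet been measured. It differs from compound 2 in one place: 2-(4-methoxyphenyl)ethyl in place of 2-phenylethenyl on an aromatic carbon. The known step bears on this only in part: it removed the methoxy and altered the link together, so the share of each is not known. Among the measured compounds shown here, compound 3 brings the methoxy back on a two-carbon link without the double bond, a combination that no measured compound shows. Because compound 2 gives 16300 nM and its step from compound 1 was only modest, the expectation is a number near compound 2, with a slight lean toward higher. The step is expected to be a 1.3-fold higher number from compound 2 to compound 3 (0.13 log units; within the scatter). For compound 3 the estimate is 22000 nM, within a range of 8000 nM to 60000 nM.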

Compound 3, half-maximal inhibitory concentration: 26300 nM
For compound 3 the middle estimate is 1.2-fold (0.08 log units) below the measured one; the measured number falls inside the stated range.
By their numbers in this assay, from the lowest: compounds 2, 3 and 1 (each within the scatter of the next, the first and the last beyond it).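

In this assay, comparing the carbonyl link with a two-carbon link while keeping the 4-methoxyphenyl gives a 1.7-fold lower number from compound 1 to compound 3 (0.23 log units; within the scatter) and so stays within the scatter, which the earlier pair, where link and methoxy changed together, could not show. Removing the double bond of the link and adding the methoxy in one move gives a 1.6-fold higher number from compound 2 to compound 3 (0.21 log units; within the scatter) and also stays within the scatter. At this position, meta to a carboxy group, only a 2.7-fold lower number from compound 1 to compound 2 (0.43 log units; beyond the scatter) remains beyond the scatter, and nothing measured alongside these numbers speaks to what lies behind them.

The methoxy and the double bond remain tangled in these steps, and a plain 2-phenylethyl group or a 2-(4-methoxyphenyl)ethenyl group at this position would be needed to separate them. Also open, going by these compounds, is how an amide link, an ether oxygen or a longer chain in the link would read in this assay, and whether a chloro group could stand in for the methoxy.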